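A few compounds are considered here, and "the series" means these few. Any claim that something is new, unique, unknown or untested is made for them only; others in the source may bear on it.

Measured so far:
Compound 1: `N=C(N)c1ccc(-c2ccc(-c3cc(Cl)cc(Cl)c3)s2)cc1` — 1570 nM
Compound 2: `N=C(N)c1ccc(-c2ccc(-c3ccc(F)cc3)s2)cc1` — 1590 nM

Both compounds were tested in a functional assay on SN12C cells (Homo sapiens) for inhibition, read by sulforhodamine B assay, with a stated time of 48 h; a lower number here means a stronger inhibitor of growth, a higher number a weaker inhibitor of growth. In this assay compound 1 gives 1570 nM, and compound 2 gives 1590 nM. On the numbers shown, compound 2 stands at the higher of the two, but its nearest neighbour is compound 1 and the gap between them lies within the usual scatter of repeated measurements, so the two cannot be told apart on this evidence.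

The next compound, compound 3 `N=C(N)c1ccc(-c2ccc(-c3ccc(Cl)cc3)s2)cc1`, has not yet been measured in this assay. Compared with compound 2 it differs in one place: chloro in place of fluoro on an aromatic carbon. Going by the values given here, nothing among the measured compounds isolates this kind of exchange, so there is no measured step to lean on. Because compound 1 gives 1570 nM and compound 2 gives 1590 nM in this assay with different substituents on the same outer ring, the step of a 1.1-fold lower number from compound 2 to compound 3 (0.06 log units; within the scatter) from compound 2 to compound 3 is expected to be small, with no change beyond the scatter in either direction. Compound 3 is therefore estimated at 1400 nM, with a likely range from 600 nM to 3500 nM.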

Compound 3, concentration for 50% growth inhibition: 180 nM
Beside the measured number, compound 3's estimate is 7.8-fold (0.89 log units) above it; the measured number lies below the stated range.
By their numbers in this assay, from the lowest: compound 3; then compounds 1 and 2 (each within the scatter of the next).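

In this assay, going from 4-fluorophenyl to 4-chlorophenyl gives an 8.8-fold lower number from compound 2 to compound 3 (0.95 log units; beyond the scatter), which shows that the result at this place, para to a large group, depends on which halogen it carries. The earlier compounds shown here could not show this: no measured pair isolated a single exchange, and the close values of compound 1 and compound 2 gave no hint that one atom could matter here. This exchange swaps one heavy atom for one heavy atom, with no ring, hydrogen-bond donor, hydrogen-bond acceptor or net charge entering or leaving, yet the step lies beyond the scatter, and nothing measured here explains it.

The compounds shown leave open whether the stronger growth inhibition is particular to chloro or would also appear with other groups at this place, such as bromo, methyl, methoxy or an amine. They also leave open whether the unsubstituted phenyl ring, with plain hydrogen at this place, would sit nearer to compound 2 or to compound 3, which would show whether chloro improves the number or fluoro holds it back.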